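Swapping the Aryl Group on the Sulfonyl Sulfur

This account rests on a few compounds, and the source may have more. Where it says the series, first, only, none or still open, it means among the compounds named here.

Three measured compounds share one core and differ only in the group on the sulfonyl sulfur. In an assay on isolated protein for inhibition of malate dehydrogenase, mitochondrial (Sus scrofa), with stated times of 45 min and 30 min (on this read-out higher numbers stand for weaker inhibition and lower numbers for stronger inhibition), compound 1 `COc1ccc(S(=O)(=O)Nc2ccc(-c3nc4ccccc4o3)cc2)cc1` gives > 63000 nM, which is a limit of the assay rather than a number. Compound 2 `O=S(=O)(Nc1ccc(-c2nc3ccccc3o2)cc1)c1ccccc1C(F)(F)F` in this assay gives > 63000 nM, again a limit. Compound 3 `O=S(=O)(Nc1ccc(-c2nc3ccccc3o2)cc1)c1ccccc1O` in this assay gives > 63000 nM, also a limit. Compound 3 thus stands where the other two stand, all three values sitting at the limit of > 63000 nM in this assay, at which 3 of the 3 values shown sit. The step that the two limits leave unreadable from compound 1 to compound 3 and the step that the two limits leave unreadable from compound 2 to compound 3 therefore have no readable size.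

Compound 4 `Cc1cccc(S(=O)(=O)Nc2ccc(-c3nc4ccccc4o3)cc2)c1` carries the change (3-methylphenyl in place of 2-hydroxyphenyl on a sulfonyl sulfur). The two measured steps that bear on it, a step that the two limits leave unreadable from compound 1 to compound 3 and a step that the two limits leave unreadable from compound 2 to compound 3, both end at the limit, so they offer no size to lean on. Among the measured compounds, every swap of the group on the sulfonyl sulfur so far gave a value at the limit, and nothing points away from it. Compound 4 is therefore expected to give 100000 nM, within 30000 nM to 400000 nM, in this assay. The expected step that the limit leaves unreadable from compound 3 to compound 4 is none beyond the scatter, with a further limit the most likely outcome.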

Compound 4, half-maximal inhibitory concentration: > 63000 nM
Compound 4 was reported as a limit; the forecaster's own chance of this, stated with the estimate: 80%; the middle value does not contradict the limit.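

Compound 4 gives only a limit, so the steps to it from compound 3 and from compound 1 cannot be read. The values shown all sit at the same place: the limit of > 63000 nM in this assay, at which 4 of the 4 values shown sit. The compounds shown leave open whether any group on the sulfonyl sulfur of the shared core can give a measurable value in this assay.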